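The source may report more compounds than this note shows. Statements on the series, on what has been measured and on what is new or still open speak of the compounds shown alone.

Measured in a functional assay on A549 cells (Homo sapiens) for inhibition, read by CCK-8 assay, with a stated time of 72 h, tested at 10 uM; on this read-out lower numbers stand for less inhibition of growth and higher numbers for more inhibition of growth at the one concentration tested:

- Compound 1 `CN(C)C(=O)c1cc2cnc(Nc3ccc(NC(=O)C4(C(=O)Nc5cccc(F)c5)CC4)cc3)nc2n1C1CCCC1`: 91.8%
- Compound 2 `CN(C)C(=O)c1cc2cnc(Nc3ccc(NC(=O)C4(C(=O)Nc5cccc(Cl)c5)CC4)cc3)nc2n1C1CCCC1`: 90.7%
- Compound 3 `CN(C)C(=O)c1cc2cnc(Nc3ccc(NC(=O)C4(C(=O)Nc5ccc(Br)cc5)CC4)cc3)nc2n1C1CCCC1`: 90.3%

Compound 3 stands level with the other two, since all three values lie within the scatter of one another. Compound 4 `COC(=O)c1cccc(NC(=O)C2(C(=O)Nc3ccc(Nc4ncc5cc(C(=O)N(C)C)n(C6CCCC6)c5n4)cc3)CC2)c1` keeps the shared core and alters only the aromatic group on the outer amide: 3-(methoxycarbonyl)phenyl in place of 4-bromophenyl on an amide-type nitrogen. In words, this puts 3-(methoxycarbonyl)phenyl in place of 4-bromophenyl on an amide-type nitrogen.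

Three measured steps change this same part of the molecule: a number 1.1 percentage points lower from compound 1 to compound 2 (within the scatter), a number 1.5 percentage points lower from compound 1 to compound 3 (within the scatter) and a number 0.4 percentage points lower from compound 2 to compound 3 (within the scatter). All three are small, so swapping one halogen-bearing phenyl for another barely moved this assay. For the measured compounds named here, none of the measured compounds carries a methoxycarbonyl group, however, so these steps are only a rough guide. No step beyond the scatter is expected, and the expected change is a number 3.3 percentage points lower from compound 3 to compound 4 (within the scatter). The estimate for compound 4 is 87%. Its expected range runs from 72% to 96%, reaching further down than up.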

Compound 4, percent growth inhibition at one concentration: 91%
Compound 4: middle estimate off by 4 percentage points, on the low side; low and high end bracket the measured number.
By their numbers in this assay, from the lowest: compounds 3, 2, 4 and 1 (each within the scatter of the next).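

Until now this position on the amide-type nitrogen had carried only halogen-bearing phenyl groups, and in this assay 3-(methoxycarbonyl)phenyl, which brings hydrogen-bond acceptors that 4-bromophenyl lacks, gives a small step (a number 0.7 percentage points higher from compound 3 to compound 4 (within the scatter)). Set against the other two halogen compounds, methoxycarbonyl in place of chloro (a number 0.3 percentage points higher from compound 2 to compound 4 (within the scatter)) and in place of fluoro (a number 0.8 percentage points lower from compound 1 to compound 4 (within the scatter)) also stay small, so a group without a halogen stands level with all three earlier compounds at this one concentration. Nothing measured here explains why such different groups give such similar numbers.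

As far as these compounds go, with one concentration and values this close, it remains open whether these groups would separate at lower concentrations. From the compounds shown here alone, it is also open how a carboxylic acid or an amine on this phenyl ring, or a plain alkyl chain in place of the ring, would behave in this assay.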